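A few compounds are considered here, and "the series" means these few. Any claim that something is new, unique, unknown or untested is made for them only; others in the source may bear on it.

Compound 1 `CC(C)(C)c1cn(C[C@H](O)[C@H]2OC(=O)C(OCc3ccccc3)=C2OCc2ccccc2)nn1`: 35800 nM
Compound 2 `O=C1O/C(=C\Cn2cc(-c3cc(F)cc(F)c3)nn2)C(OCc2ccccc2)=C1OCc1ccccc1`: > 100000 nM
Compound 3 `CCCCCc1ccc(-c2cn(C/C=C3\OC(=O)C(OCc4ccccc4)=C3OCc3ccccc3)nn2)cc1`: > 100000 nM

Going by the values given here, compound 1 holds the only plain number in a functional assay on SW-620 cells (Homo sapiens) for antiproliferative activity, read by MTT assay, with a stated time of 72 h (a higher number here means a weaker inhibitor, a lower number a stronger inhibitor), where compound 1 gives 35800 nM. For compound 2 the assay reports only a limit, > 100000 nM. For compound 3 it likewise reports only a limit, > 100000 nM. The step that the two limits leave unreadable from compound 2 to compound 3 is therefore unreadable, both compounds sitting at the limit of > 100000 nM in this assay, at which 2 of the 3 values shown sit. Compound 4 `Cc1ccc(-c2cn(C[C@H](O)[C@H]3OC(=O)C(OCc4ccccc4)=C3OCc3ccccc3)nn2)cc1` differs from compound 1 by 4-methylphenyl in place of tert-butyl on an aromatic carbon. Among the compounds with values here, no measured step covers this change on the core of compound 1; compounds 2 and 3, which carry aromatic groups on the triazole, reach only (the limit of > 100000 nM in this assay, at which 2 of the 3 values shown sit), so a drift toward weaker inhibition is expected. Compound 4 is thus estimated at 55000 nM, between 15000 nM and 150000 nM. The expected step of a 1.5-fold higher number from compound 1 to compound 4 (0.19 log units; within the scatter) is modest.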

Compound 4, half-maximal inhibitory concentration: > 100000 nM
Compound 4 was reported as a limit; the forecaster's own chance of this, stated with the estimate: 40%; at least 1.8-fold (0.25 log units) between middle value and limit.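

In this assay, going by these compounds alone, 4-methylphenyl in place of tert-butyl on this aromatic carbon gives an at least 2.7-fold higher number from compound 1 to compound 4 (0.44 log units; beyond the scatter), the first readable step at this position. As far as these compounds go, the result for compound 4 is only a limit, so the full size of the step stays unknown. Compound 4 now joins the compounds that give no plain number: the limit of > 100000 nM in this assay, at which 3 of the 4 values shown sit.

The compounds shown leave open whether the loss follows from the aromatic ring itself. A cyclohexyl or aminomethyl group on this carbon would test whether a plain number returns on the core of compound 1.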